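Replacing the dibromo-aminophenyl arm of a vinyl sulfone

The source may hold more compounds than are shown below. What is called first, only, known or untested is meant among the compounds shown, and "the series" means these compounds.

Compound 1, `Nc1c(Br)cc(Br)cc1/C=C(\C(=O)c1ccc(Br)cc1)S(=O)(=O)c1ccc(Br)cc1`, gives 25000 nM.
Compound 2, `COc1cc(OC)c(/C=C(\C(=O)c2ccc([N+](=O)[O-])cc2)S(=O)(=O)Cc2ccc(Cl)cc2)c(OC)c1`, gives 10000 nM.
Compound 3, `Nc1c(Br)cc(Br)cc1/C=C(/Sc1ccc(Br)cc1)C(=O)c1ccc(Br)cc1`, gives > 100000 nM.

Of the compounds shown here, three have been measured in a functional assay on DU-145 cells (Homo sapiens) for inhibition, read by trypan blue exclusion, with a stated time of 96 h; on this read-out higher numbers stand for weaker inhibition of growth and lower numbers for stronger inhibition of growth. Compound 1 holds the highest of the two numbers, with compound 2 its nearest neighbour at a lower number that lies beyond the scatter. Compound 3 returned no number, only a limit of the assay. That result is the limit of > 100000 nM in this assay, at which 1 of the 3 values shown sits. Among the measured compounds shown here, the one step that can be read between measured compounds is an at least 4.0-fold higher number from compound 1 to compound 3 (0.60 log units; beyond the scatter), which concerns the group on the other double-bonded chain carbon and not the aryl arm considered here.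

The untested compound 4, `COc1ccc(/C=C(\C(=O)c2ccc(Br)cc2)S(=O)(=O)c2ccc(Br)cc2)c(F)c1`, differs from compound 1 by 2-fluoro-4-methoxyphenyl in place of 2-amino-3,5-dibromophenyl on a double-bonded chain carbon bound to a double-bonded chain carbon. For the measured compounds named here, no measured pair changes this aryl arm, so no step among the three compounds bears directly on it. The account therefore expects no movement beyond the scatter, with a wide band around that expectation. For compound 4 the estimated value is 20000 nM, ranging from 5000 nM to 80000 nM, which means an expected step of a 1.3-fold lower number from compound 1 to compound 4 (0.10 log units; within the scatter).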

Compound 4, concentration for 50% growth inhibition: 10000 nM
Compound 4: middle estimate off by 2.0-fold (0.30 log units), on the high side; the measured number falls inside the stated range.
By their numbers in this assay, from the lowest: compounds 2 and 4 (each within the scatter of the next); then compound 1. At a limit, above all of these: compound 3.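

In this assay, among the compounds shown here, the arm on the double-bonded chain carbon bound to a double-bonded chain carbon can be exchanged whole, a change no earlier pair touched, and the step is a 2.5-fold lower number from compound 1 to compound 4 (0.40 log units; beyond the scatter). So 2-amino-3,5-dibromophenyl is not needed for the growth inhibition seen with compound 1: 2-fluoro-4-methoxyphenyl, with 0 hydrogen-bond donors and neither bromine, serves on the same core and gives the lower number. Nothing measured in this set accounts for the size of this step, and no cause can be assigned to it.

The exchange replaces the amine, both bromines, the fluorine and the methoxy group in a single move, so the compounds shown do not tell which of these groups carries the difference, and a plain 4-methoxyphenyl arm without the fluorine or a 2-aminophenyl arm without the bromines would begin to separate them. Also open, on these data alone, is whether (4-bromophenyl)sulfanyl in place of (4-bromophenyl)sulfonyl would weaken growth inhibition on the 2-fluoro-4-methoxyphenyl arm as it does on the arm of compound 1.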